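Compound 4: a methoxy swap on compound 3

The source may hold more compounds than are shown below. What is called first, only, known or untested is meant among the compounds shown, and "the series" means these compounds.

Values in a functional assay on HepG2 cells (Homo sapiens) for inhibition, read by MTT assay, with a stated time of 48 h; on this read-out lower numbers stand for stronger inhibition and higher numbers for weaker inhibition
compound 1 `c1ccc(-c2nn(-c3ccccc3)c3nccc(-c4cccs4)c23)cc1` gives 39300 nM
compound 2 `c1ccc(-c2ccnc3c2c(-c2ccccc2)nn3-c2ccccc2)cc1` gives 3210 nM
compound 3 `Cc1ccc(-c2ccnc3c2c(-c2ccccc2)nn3-c2ccccc2)cc1` gives 10700 nM

Compound 3 holds the middle place among these three numbers, with one step on each side (a 3.3-fold higher number from compound 2 to compound 3 (0.52 log units; beyond the scatter) and a 3.7-fold lower number from compound 1 to compound 3 (0.57 log units; beyond the scatter)). The next compound, compound 4 `COc1ccc(-c2ccnc3c2c(-c2ccccc2)nn3-c2ccccc2)cc1`, alters one group of compound 3: methoxy in place of methyl on an aromatic carbon, para to a large group (methoxy in place of methyl on an aromatic carbon). Put another way, 4-methylphenyl becomes 4-methoxyphenyl.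

The closest measured change sits at the same place, methyl in place of hydrogen, and that step was modest (a 3.3-fold higher number from compound 2 to compound 3 (0.52 log units; beyond the scatter)). The step from thiophen-2-yl to phenyl was large (a 12-fold lower number from compound 1 to compound 2 (1.09 log units; beyond the scatter)), but it exchanged a whole ring and so says little about swapping one small group for another. Among the measured compounds shown here, no measured compound carries methoxy, so the data do not settle the direction of the step in this assay. With a single modest example to go on, a step of modest size at most is expected, and quite possibly none beyond the scatter. The expected step is small (a 1.3-fold lower number from compound 3 to compound 4 (0.13 log units; within the scatter)). Compound 4 is estimated at 8000 nM in a range expected to run from 2500 nM to 25000 nM in this test.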

Compound 4, half-maximal inhibitory concentration: 6590 nM
For compound 4 the middle estimate is 1.2-fold (0.08 log units) above the measured one, within the range that was stated.
By their numbers in this assay, from the lowest: compound 2; then compounds 4 and 3 (each within the scatter of the next); then compound 1.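

In this assay, putting methoxy where methyl stood gives a 1.6-fold lower number from compound 3 to compound 4 (0.21 log units; within the scatter), so at this position the added oxygen, with its hydrogen-bond acceptor, brings no difference that can be read. Against hydrogen on the same aromatic carbon, para to a large group, methoxy gives a 2.1-fold higher number from compound 2 to compound 4 (0.31 log units; beyond the scatter) and methyl gives a 3.3-fold higher number from compound 2 to compound 3 (0.52 log units; beyond the scatter), so both of these small groups now point the same way, towards a higher number than hydrogen, though the methoxy step lies close to the edge of the scatter. With a 6.0-fold lower number from compound 1 to compound 4 (0.78 log units; beyond the scatter), 4-methoxyphenyl also joins phenyl and 4-methylphenyl in giving a lower number than thiophen-2-yl, and none of the four compounds goes against that pattern.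

No measurement at hand gives a reason for any of these steps. Still open, on these data alone, is whether any other group on this carbon, such as an amine, a carboxylic acid or a longer chain like ethoxy, would match hydrogen or reach a lower number than it does, and whether moving methoxy elsewhere on the ring would change the picture.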